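Series notes: benzyl for cyclohexyl on the imidazole nitrogen

A few compounds are considered here, and "the series" means these few. Any claim that something is new, unique, unknown or untested is made for them only; others in the source may bear on it.

Measured so far in a functional assay on SNB-75 cells (Homo sapiens) for inhibition, read by sulforhodamine B assay, with a stated time of 48 h, tested at 10 uM; a higher number here means more inhibition at the concentration tested (going by the name of the read-out), a lower number less inhibition:
compound 1 `c1ccc2c(-c3cn4ccnc4c(-c4ccc5ncn(C6CCCCC6)c5c4)n3)cccc2c1`, 16.5%;
compound 2 `Fc1ccccc1-c1cn2ccnc2c(-c2ccc3ncn(C4CCCCC4)c3c2)n1`, 29.7%;
compound 3 `c1cn2cc(-c3ccc4c(c3)ncn4C3CCCCC3)nc(-c3ccc4ncn(C5CCCCC5)c4c3)c2n1`, 24.8%.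

Compound 3 stands second highest of the three numbers; its gaps to compound 2 and to compound 1 both lie within the scatter, so no order among them is claimed. Compound 4 `c1ccc(Cn2cnc3ccc(-c4nc(-c5ccc6c(c5)ncn6C5CCCCC5)cn5ccnc45)cc32)cc1` differs from compound 3 by benzyl in place of cyclohexyl on an aromatic nitrogen. Among the measured compounds shown here, the one measured step, a number 13.2 percentage points higher from compound 1 to compound 2 (beyond the scatter), concerns a replacement on an aromatic carbon and does not touch the ring nitrogen, so no measured step bears on this change. With nothing to point either way, the step of a number 0.2 percentage points higher from compound 3 to compound 4 (within the scatter) is expected to stay within the scatter. Compound 4 is therefore estimated at 25%, with a range of 10% to 40%.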

Compound 4, a percentage reported as inhibition, at one concentration (the size of the read-out at that concentration, not a potency): -67.4%
Compound 4: middle estimate off by 92.4 percentage points, on the high side, and the stated range ends above it.
By their numbers in this assay, from the lowest: compound 4; then compounds 1, 3 and 2 (each within the scatter of the next, the first and the last beyond it).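

The substituent on this aromatic nitrogen matters in this assay: benzyl in place of cyclohexyl gives a number 92.2 percentage points lower from compound 3 to compound 4 (beyond the scatter) and leaves compound 4 at -67.4% as a negative reading. No evidence on the origin of this drop is at hand.

Open, going by these compounds, is whether the drop belongs to benzyl alone or would also follow from phenyl or a longer chain ending in an amine on this nitrogen. Also open, on these data alone, is whether benzyl on the other ring nitrogen, which keeps cyclohexyl in compound 4, would read the same way.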